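Toll-like receptor 8 agonist series: notes toward compound 4

A few compounds are considered here, and "the series" means these few. Any claim that something is new, unique, unknown or untested is made for them only; others in the source may bear on it.

Measured so far in an assay on isolated protein for agonist activity at Toll-like receptor 8 (Homo sapiens); on this read-out lower numbers stand for an effect already at smaller amounts and higher numbers for an effect only at larger amounts of compound:
compound 1 `CCC[C@H](CCO)Nc1nc(N)nnc1OCc1nccc(OC)c1OC`, 560 nM
compound 2 `CCCCNc1nc(N)nnc1OCc1ccccn1`, 330 nM
compound 3 `CCOC(=O)C1=Cc2ccc(-c3cccc(C#N)c3)cc2N=C(N)C1`, 15000 nM

Compound 2 shows the lowest of the three numbers in this assay. Compound 1 sits within the scatter of it, so no order between compound 1 and compound 2 can be read; compound 3 lies well beyond the scatter, far higher.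

Compound 4 `CCCCNc1nc(N)nnc1OCCCN(C)C` is not yet measured. It keeps the core of compound 2 and changes only the ether substituent: 2-(dimethylamino)ethyl in place of pyridin-2-yl on a saturated chain carbon bound to an oxygen on an aromatic ring.

Within the data shown here, no measured pair shows such a change, so the size of the step is uncertain. A basic chain in place of a ring is expected to cost some activity, and the estimated step of a 2.1-fold higher number from compound 2 to compound 4 (0.33 log units; beyond the scatter) is set as a modest loss, around the edge of the scatter. Compound 4 is expected to give 700 nM, with a range from 200 nM to 3000 nM.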

Compound 4, half-maximal effective concentration: 100 nM
Compound 4: the middle estimate sits 7.0-fold (0.85 log units) above what was measured; the measured number lies below the stated range.
By their numbers in this assay, from the lowest: compound 4; then compounds 2 and 1 (each within the scatter of the next); then compound 3.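

At this place, on a saturated chain carbon bound to an oxygen on an aromatic ring, the pyridin-2-yl ring can be given up in this assay: 2-(dimethylamino)ethyl in its place gives a 3.3-fold lower number from compound 2 to compound 4 (0.52 log units; beyond the scatter). This single pair shows that an open chain ending in dimethylamino can serve here, with no ring in the substituent. Nothing on hand accounts for the gain.

Going by these compounds, it remains open whether the step depends on the amine nitrogen or on the chain. A plain alkyl chain without the amine, a primary amine or a longer chain would separate these.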